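Halogen swap on compound 3: chloro to iodo

The source may hold more compounds than are shown below. What is called first, only, known or untested is meant among the compounds shown, and "the series" means these compounds.

Compound 3 `C=C1C(n2cc(Cl)c(N)nc2=O)O[C@H](CO)[C@@H]1O` sits at the limit of a functional assay on L1210 cells (Mus musculus) for cytotoxicity; on this read-out lower numbers stand for stronger inhibition and higher numbers for weaker inhibition: compound 3 gives > 100 ug/mL, a limit rather than a number. the limit of > 100 ug/mL in this assay, at which 2 of the 3 values shown sit, describes where compound 3 stands. Compound 1 `C=C1C(n2cc(F)c(=O)[nH]c2=O)O[C@H](CO)[C@@H]1O` also gives only a limit, > 100 ug/mL, in this assay. Compound 2 `C=C1C(n2cc(C)c(=O)[nH]c2=O)O[C@H](CO)[C@@H]1O` gives 50 ug/mL in this assay. Among the measured compounds shown here, the single measured step, an at least 2.0-fold lower number from compound 1 to compound 2 (0.30 log units; that floor lies within the scatter), concerns a different ring than the change here and does not reach beyond the scatter. Compound 4 `C=C1C(n2cc(I)c(N)nc2=O)O[C@H](CO)[C@@H]1O` differs from compound 3 by iodo in place of chloro on an aromatic carbon. For the measured compounds named here, no measured step bears on this change on the shared core. Compound 4 is expected to stay at or near the limit, and compound 4 is estimated at 100 ug/mL, with a range from 30 ug/mL to 300 ug/mL. The step of a number no higher from compound 3 to compound 4 (the limit leaves the size open) is thus expected to be none beyond the scatter.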

Compound 4, half-maximal inhibitory concentration: > 100 ug/mL
Compound 4: no number, only a limit; the forecaster's own chance of this, stated with the estimate: 70%; the middle value sits exactly at the limit.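

In this assay compound 3 and compound 4 both give only a limit, so no step can be read for iodo in place of chloro: the limit of > 100 ug/mL in this assay, at which 3 of the 4 values shown sit.

The compounds shown leave open how compound 3 and compound 4 compare, and whether any group on this aromatic carbon gives a readable number on their shared core.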